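Cyclopentyl in Place of a Methoxyethyl Chain on the Amide

This account rests on a few compounds, and the source may have more. Where it says the series, first, only, none or still open, it means among the compounds named here.

Compound 1 `COCCNC(=O)c1cc2cccc(OC)c2oc1=N` is one of two compounds with a measured value here. In an assay on HeLa cells for displacement of a labelled ligand from adenosine receptor A3 (Homo sapiens), read by scintillation counting, with a stated time of 180 min, tested at 10 uM (on this read-out higher numbers stand for more inhibition at the one concentration tested (going by the name of the read-out) and lower numbers for less inhibition), compound 1 gives 15%. Compound 2 `COc1cccc2cc(C(=O)NCC(=O)O)c(=O)oc12` shares the same core and in this assay gives 15%, so compound 1 stands level with compound 2 at the digits shown, a difference well within the scatter of the method. Neither compound shows much inhibition at the single concentration tested.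

Compound 3 `COc1cccc2cc(C(=O)NC3CCCC3)c(=N)oc12` has not yet been measured. It differs from compound 1 in one place: cyclopentyl in place of 2-methoxyethyl on an amide-type nitrogen. Within the data shown here, no pair of measured compounds differs by a single change, so there is no measured step to lean on. Both measured values sit low and close together, which gives no ground to expect a large move in either direction; a change of no more than the scatter seems the fairest expectation for the step from compound 1 to compound 3, estimated as no change at the digits printed from compound 1 to compound 3 (within the scatter). Compound 3 is therefore estimated at 15%, with a plausible range from 0% to 35%.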

Compound 3, a percentage reported as inhibition, at one concentration (the size of the read-out at that concentration, not a potency): 20%
The estimate for compound 3 lay 5 percentage points below the measured number, and the stated range covers the measured number.
By their numbers in this assay, from the lowest: compounds 1, 2 and 3 (each within the scatter of the next).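

In this assay, among these compounds, cyclopentyl in place of 2-methoxyethyl on the amide-type nitrogen gives a number 5 percentage points higher from compound 1 to compound 3 (within the scatter) and is the first step here that changes one place only. An open chain with one hydrogen-bond acceptor and a ring of carbon only, with no such acceptor, therefore read alike at this position, and inhibition stays small at the one concentration tested. Nothing measured here explains this result.

From the compounds shown here alone, what a benzyl group or a 2-aminoethyl chain on the same nitrogen would give remains open. Among the compounds shown here, also open is whether any group at this position can move the read-out beyond the usual scatter, and a reading at one concentration gives no potency for either compound.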